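This account rests on a few compounds, and the source may have more. Where it says the series, first, only, none or still open, it means among the compounds named here.

Measured so far in a functional assay on A549 cells (Homo sapiens) for antiproliferative activity, read by MTT assay, with a stated time of 48 h; a lower number here means a stronger inhibitor, a higher number a weaker inhibitor:
- compound 1 `C#Cc1cccc(Nc2ncnc3cc(NC(=O)/C=C/c4ccccc4)sc23)c1` gives 26200 nM
- compound 2 `O=C(/C=C/c1ccc(O)cc1)Nc1cc2c(Nc3ccc(Cl)c(Cl)c3)ncnc2s1` gives 34300 nM
- compound 3 `COc1ccc(/C=C/C(=O)Nc2cc3c(Nc4ccc(Cl)c(Cl)c4)ncnc3s2)cc1` gives 3320 nM

Compound 1 at 26200 nM lies within the scatter of compound 2 at 34300 nM and well above compound 3 at 3320 nM on these numbers.

Compound 4 `N#Cc1cccc(Nc2ncnc3cc(NC(=O)/C=C/c4ccccc4)sc23)c1` differs from compound 1 by a single change cyano in place of ethynyl on an aromatic carbon and this is cyano in place of ethynyl on an aromatic carbon, meta to a large group.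

Among the compounds with values here, the one measured step is a 10-fold lower number from compound 2 to compound 3 (1.01 log units; beyond the scatter) and it is large, but it is methyl in place of hydrogen on an oxygen on an aromatic ring, so it gives no measure for the present swap. Within the data shown here, no measured step involves ethynyl or cyano. In this assay no shift beyond the scatter is therefore expected, and the starting point remains compound 1 at 26200 nM in this comparison.

The expected step is a 1.0-fold lower number from compound 1 to compound 4 (0.02 log units; within the scatter) and it is not expected to leave the scatter. For compound 4 the estimated value is 25000 nM with an expected range from 9000 nM to 60000 nM in this read-out.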

Compound 4, half-maximal inhibitory concentration: 17200 nM
Compound 4: middle estimate off by 1.5-fold (0.16 log units), on the high side; the range from low to high includes it.
By their numbers in this assay, from the lowest: compound 3; then compounds 4, 1 and 2 (each within the scatter of the next).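

In this assay, cyano in place of ethynyl on an aromatic carbon, meta to a large group, gives a 1.5-fold lower number from compound 1 to compound 4 (0.18 log units; within the scatter), so the two groups cannot be told apart at this position on these numbers. The change from 3-ethynylphenyl to 3-cyanophenyl adds a hydrogen-bond acceptor by count at the same heavy-atom count, and the read-out stays within the scatter. No measurement at hand offers an explanation for this result.

Going by these compounds, whether an amine, a carboxylic acid or a longer chain on the same aromatic carbon would give a step beyond the scatter remains open. Also open, on these data alone, is whether cyano and ethynyl stay this close on another core or with another amide group.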